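Aryl amide variation on a diflurophenyl acetoxybenzamide core

The source may hold more compounds than are shown below. What is called first, only, known or untested is meant among the compounds shown, and "the series" means these compounds.

Compound 1 `CNC(=O)c1cc(-c2ccc(F)cc2F)ccc1OC(C)=O` gives 29.9% in a functional assay on the whole organism (strain Kunming) for inhibition, with Mus musculus as the target, in the writhing test, at a dose of 40 mg/kg by the oral route; a higher number here means more inhibition at the dose given (going by the name of the read-out), a lower number less inhibition. Compound 2 `CC(=O)Oc1ccc(-c2ccc(F)cc2F)cc1C(=O)NCc1ccccc1` gives 16.6%. Compound 3 `CC(=O)Oc1ccc(-c2ccc(F)cc2F)cc1C(=O)Nc1ccccc1C` gives 12.3%.

Compound 3 holds the lowest of the three numbers; its distance to compound 2 is within the scatter, so the two cannot be ordered, while compound 1 stands clearly higher, as the step of a number 17.6 percentage points lower from compound 1 to compound 3 (beyond the scatter) shows. Compound 4 `CC(=O)Oc1ccc(-c2ccc(F)cc2F)cc1C(=O)Nc1ccc(Cl)cc1` differs from compound 3 by 4-chlorophenyl in place of 2-methylphenyl on an amide-type nitrogen.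

Within the data shown here, no measured step exchanges one aryl group on the amide nitrogen for another, so nothing bears on this change directly. The two steps that touch the amide nitrogen, a number 13.3 percentage points lower from compound 1 to compound 2 (beyond the scatter) and a number 17.6 percentage points lower from compound 1 to compound 3 (beyond the scatter), each lowered the number modestly when a larger group replaced a small one; the step of a number 4.3 percentage points lower from compound 2 to compound 3 (within the scatter), between two larger groups of similar size, stayed within the scatter. Since compound 4 keeps a group of the same size and kind at the same place, the expected step of a number 1.7 percentage points higher from compound 3 to compound 4 (within the scatter) is none beyond the scatter. Compound 4 is therefore estimated at 14% in this assay, with a range from 4% to 28%.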

Compound 4, a percentage reported as inhibition, in the whole organism at one dose (the size of the read-out at that dose, not a potency): 29.9%
The estimate for compound 4 lay 15.9 percentage points below the measured number, and the stated range ends below it.
By their numbers in this assay, from the lowest: compounds 3 and 2 (each within the scatter of the next); then compounds 1 and 4 (each within the scatter of the next).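

On the amide nitrogen, this assay separates two aryl groups that have the same count of heavy atoms: putting 4-chlorophenyl in place of 2-methylphenyl gives a clear rise (a number 17.6 percentage points higher from compound 3 to compound 4 (beyond the scatter)), so size and kind of group alone do not set the number at this position. The same group also stands clear of benzyl (a number 13.3 percentage points higher from compound 2 to compound 4 (beyond the scatter)) but shows no separation from the much smaller methyl (no change at the digits printed from compound 1 to compound 4 (within the scatter)), which means that compound 4 goes against the fall seen with compounds 2 and 3 when a larger group replaced methyl. Nothing available here explains why the two aryl groups differ.

The compounds shown leave open whether the result follows from the chlorine, from its place on the ring or from the absence of the methyl group, since 2-chlorophenyl, 4-methylphenyl and plain phenyl do not appear among them. They also leave open how a 4-methoxyphenyl or 4-fluorophenyl group on the same nitrogen would read in this assay.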